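Morpholinylcarbonyl for pivaloyl on the pyrrolidine amide of a sulfonamide series

The source may hold more compounds than are shown below. What is called first, only, known or untested is meant among the compounds shown, and "the series" means these compounds.

Measured compounds:
compound 1, `O=C(CN1CCCC1)N1CCC(NS(=O)(=O)c2cc(S(=O)(=O)c3ccccc3)ccc2C(F)(F)F)CC1`, 25000 nM
compound 2, `CC(C)(C)OC(=O)N1CCC[C@@H]1C(=O)N1CCC(NS(=O)(=O)c2cc(S(=O)(=O)c3ccccc3)ccc2C(F)(F)F)CC1`, 25000 nM
compound 3, `CC(C)(C)C(=O)N1CCC[C@H]1C(=O)N1CCC(NS(=O)(=O)c2cc(S(=O)(=O)c3ccccc3)ccc2C(F)(F)F)CC1`, 50000 nM

In a physicochemical assay for solubility (a higher number here means a more soluble compound, a lower number a less soluble compound), compound 3 gives 50000 nM. On the numbers shown it sits at the upper end of the three, but a 2.0-fold higher number from compound 1 to compound 3 (0.30 log units; within the scatter) and a 2.0-fold higher number from compound 2 to compound 3 (0.30 log units; within the scatter) both lie within the scatter, as does no change at the digits printed from compound 1 to compound 2 (within the scatter), so no ordering among the measured compounds can be claimed.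

Compound 4 is `O=C([C@@H]1CCCN1C(=O)N1CCOCC1)N1CCC(NS(=O)(=O)c2cc(S(=O)(=O)c3ccccc3)ccc2C(F)(F)F)CC1`. It differs from compound 3 in one place: morpholin-4-yl in place of tert-butyl on a carbonyl carbon. Among the compounds with values here, the steps that bear on this are those that change the group on the same carbonyl carbon: a 2.0-fold higher number from compound 2 to compound 3 (0.30 log units; within the scatter) and a 2.0-fold higher number from compound 1 to compound 3 (0.30 log units; within the scatter), neither of which moved the read-out beyond the scatter. Within the data shown here, nothing among the measured compounds contains a morpholin-4-yl group, so the step to compound 4 is expected to be no change at the digits printed from compound 3 to compound 4 (within the scatter), that is, no change beyond the scatter. Compound 4 is therefore estimated at 50000 nM, with a range from 25000 nM to 100000 nM.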

Compound 4, solubility: 50000 nM
Compound 4: the middle estimate sits on the measured number at the digits printed, and the stated range covers the measured number.
By their numbers in this assay, from the lowest: compounds 1, 2, 3 and 4 (each within the scatter of the next).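

At the carbonyl carbon whose other neighbour is the amide-type nitrogen in a ring, the exchange of tert-butyl for morpholin-4-yl gives no change at the digits printed from compound 3 to compound 4 (within the scatter) in this assay. This extends the flat picture at this carbon to a group carrying a six-membered non-aromatic ring with 2 hetero atoms and a hydrogen-bond acceptor, whereas the earlier 2.0-fold higher number from compound 2 to compound 3 (0.30 log units; within the scatter) involved no ring directly on this carbonyl carbon. No supporting data are available to explain this result.

On these data alone, all four compounds remain within the scatter of their neighbours in the ordering, so it is open whether any group at this carbonyl carbon can shift the read-out beyond it. A piperazin-1-yl group or a chain ending in a carboxylic acid would test this.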